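This account rests on a few compounds, and the source may have more. Where it says the series, first, only, none or still open, it means among the compounds named here.

Measured compounds in a toxicity assay on NIH3T3 cells (Mus musculus) for cytotoxicity, read by resazurin assay; a higher number here means that more compound is needed for the effect, a lower number that less compound is needed:
compound 1, `CC(C)c1ccc(Cn2cncc2CNc2ccc(-c3nc4ccccc4s3)c(-c3ccccc3)c2)cc1`: > 1000 nM
compound 2, `COC(=O)c1ccc(NCc2cncn2Cc2ccc(C#N)cc2)cc1-c1ccccc1`: > 10000 nM
compound 3, `CCc1ccc(Cn2cncc2CNc2ccc(-c3nc4ccccc4s3)c(-c3ccccc3)c2)cc1`: > 1000 nM

Each of these three values is a limit of this assay, not a number. Compound 1 sits at the limit of > 1000 nM in this assay, at which 2 of the 3 values shown sit. Compound 3 sits at that same limit. Compound 2 sits at the limit of > 10000 nM in this assay, at which 1 of the 3 values shown sits. Going by the values given here, the one step between measured compounds, a step that the two limits leave unreadable from compound 1 to compound 3, cannot be read in size; both of its values are limits.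

Compound 4, `COC(=O)c1ccc(NCc2cncn2Cc2ccccc2Br)cc1-c1ccccc1`, has not yet been measured in this assay. It differs from compound 2 by 2-bromophenyl in place of 4-cyanophenyl on a saturated chain carbon bound to an aromatic nitrogen. Among the compounds with values here, no measured step bears on this change: the only step between measured compounds, from compound 1 to compound 3, concerns a different part of the structure and was left unreadable, and compound 2 itself gives only a limit. The expectation for compound 4 therefore rests on compound 2 alone, and the step that the limit leaves unreadable from compound 2 to compound 4 is expected to be none beyond the scatter. Compound 4 is estimated at 15000 nM, within 5000 nM to 50000 nM, with a good chance that this assay again reports only a limit.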

Compound 4, half-maximal effective concentration: 10000 nM
Beside the measured number, compound 4's estimate is 1.5-fold (0.18 log units) above it, within the range that was stated.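

In this assay compound 4 gives 10000 nM, a true number and the only one among the compounds shown, so the series can reach a measurable effect in this assay with this part of the structure kept in place. Going by these compounds alone, compound 2 gives > 10000 nM, which is a limit of the assay and not a number: the limit of > 10000 nM in this assay, at which 1 of the 4 values shown sits. On a saturated chain carbon bound to an aromatic nitrogen, the change from 4-cyanobenzyl to 2-bromobenzyl therefore gives a number no higher from compound 2 to compound 4 (the limit leaves the size open), and this step, like the one between compound 1 and compound 3, cannot be read in size.

The compounds shown leave open how far compound 2 really lies from compound 4, and whether any difference goes with the loss of the nitrile, the arrival of the bromine or the ring position of the substituent, since all of these change in a single step. They also leave open what a 4-bromobenzyl, a plain benzyl or a benzyl carrying an amine or a carboxylic acid would give at this place.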